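The source may hold more compounds than are shown below. What is called first, only, known or untested is meant among the compounds shown, and "the series" means these compounds.

Compound 1, `CC1CCN(C2CCN(S(=O)(=O)c3cccc(Br)c3)CC2)CC1`, gives 3.2 nM in a functional assay on DLD-1 cells (Homo sapiens) for antiproliferative activity, read by CellTiter-Glo, with a stated time of 72 h; on this read-out lower numbers stand for stronger inhibition and higher numbers for weaker inhibition.
Compound 2, `CC1CCN(C2CCN(S(=O)(=O)c3ccc(Cl)c(Cl)c3)CC2)CC1`, gives 2.9 nM in this assay.
Compound 3, `CC1CCN(C2CCN(S(=O)(=O)c3cccc(Cl)c3)CC2)CC1`, gives only a limit of the assay, > 5000 nM, in this assay.

Compound 3 therefore stands apart from the other two measured compounds: it sits at the limit (the limit of > 5000 nM in this assay, at which 1 of the 3 values shown sits), so no number is known for it, only that it lies past that point. Compound 4, `CC1CCN(C2CCN(S(=O)(=O)c3ccc(Br)c(Cl)c3)CC2)CC1`, differs from compound 3 by bromo in place of hydrogen on an aromatic carbon. The most direct measured evidence is the step in the opposite direction: an at least 1700-fold higher number from compound 2 to compound 3 (3.23 log units; beyond the scatter), which removed a halogen from that same ring carbon and lost all measurable activity. A second halogen change, an at least 1500-fold higher number from compound 1 to compound 3 (3.19 log units; beyond the scatter), was of similar size. Compound 4 thus resembles compound 2, with bromo in place of chloro on the ring, and a 1.1-fold lower number from compound 1 to compound 2 (0.04 log units; within the scatter) shows that bromo- and chloro-bearing rings here gave numbers within the scatter of each other. Restoring a halogen at the carbon that compound 3 lacks is therefore expected to bring back strong inhibition, a large step down, an at least 1400-fold lower number from compound 3 to compound 4 (3.15 log units; beyond the scatter). Compound 4 is estimated at 3.5 nM, with a range of 1 nM to 15 nM.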

Compound 4, half-maximal inhibitory concentration: 12 nM
Beside the measured number, compound 4's estimate is 3.4-fold (0.54 log units) below it; measured number inside the range.
By their numbers in this assay, from the lowest: compounds 2 and 1 (each within the scatter of the next); then compound 4. At a limit, above all of these: compound 3.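

Bromo at this carbon, ortho to a chloro group and para to a large group, is enough on its own to restore strong inhibition in this assay, and the change from compound 3 is large: an at least 410-fold lower number from compound 3 to compound 4 (2.61 log units; beyond the scatter). The choice of halogen at this carbon still matters, though more modestly, as the swap of chloro for bromo gives a 4.1-fold higher number from compound 2 to compound 4 (0.62 log units; beyond the scatter), and the 4-bromo-3-chlorophenyl ring also ends up weaker than the 3-bromophenyl ring, with a 3.8-fold higher number from compound 1 to compound 4 (0.57 log units; beyond the scatter). An exchange of bromo and chloro can therefore be either a collapse or a small shift, depending on the compound in which it is made: the same change on two cores in this assay, an at least 1500-fold higher number (3.19 log units; beyond the scatter) from compound 1 to compound 3 and a 4.1-fold lower number (0.62 log units; beyond the scatter) from compound 4 to compound 2, at least 6400-fold (3.81 log units) apart, beyond the scatter of two such steps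

As far as these compounds go, compound 3 gives > 5000 nM, which is a limit of the assay, so the full size of the steps involving it stays open. From the compounds shown here alone, it also stays open whether a methyl group, a methoxy group or an amine at this same carbon would restore inhibition as the halogens do, or whether this recovery belongs to chloro and bromo alone.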